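A few compounds are considered here, and "the series" means these few. Any claim that something is new, unique, unknown or untested is made for them only; others in the source may bear on it.

Three compounds share one core, and they differ only at the far end of the molecule. Compound 1 `COc1cc(COc2ccc(C(=O)NN)cc2)cc(OC)c1OC` ends in a bare hydrazide, and in a physicochemical assay, with a stated time of 30 min (on this read-out higher numbers stand for weaker inhibition and lower numbers for stronger inhibition), compound 1 gives 264 ug/mL. Compound 2 `COc1cc(/C=N/NC(=O)c2ccc(OCc3cc(OC)c(OC)c(OC)c3)cc2)cc(OC)c1O` extends that hydrazide into a hydrazone carrying a further aromatic ring with a free hydroxyl, and in this assay compound 2 gives 75 ug/mL. Compound 3 `COc1cc(/C=N/NC(=O)c2ccc(OCc3cc(OC)c(OC)c(OC)c3)cc2)cc(OC)c1OC` differs from compound 2 by methyl in place of hydrogen on an oxygen on an aromatic ring. For compound 3 in this assay only a limit is recorded, > 100 ug/mL. Its exact standing is therefore open: the step of an at least 1.3-fold higher number from compound 2 to compound 3 (0.12 log units; that floor lies within the scatter) is known only as a floor, and the limit of > 100 ug/mL in this assay, at which 1 of the 3 values shown sits, marks the edge at which compound 3 sits.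

Compound 4 `COc1cc(COc2ccc(C(=O)N/N=C/c3cccc(O)c3)cc2)cc(OC)c1OC` is the next variation: 3-hydroxyphenyl in place of 3,4,5-trimethoxyphenyl on a carbon with a double bond to nitrogen. Among the measured compounds shown here, the only measured step bearing on this end is an at least 1.3-fold higher number from compound 2 to compound 3 (0.12 log units; that floor lies within the scatter), which runs from a free hydroxyl to a methyl ether and stays within the scatter at its floor. For the measured compounds named here, compound 4 brings back a free hydroxyl while dropping the methoxy groups, a change no measured pair covers. Compound 4 is expected to move as an at least 1.1-fold lower number from compound 3 to compound 4 (0.04 log units; that floor lies within the scatter), toward the neighbourhood of compound 2. The estimate for compound 4 in this assay is 90 ug/mL, with a range from 40 ug/mL to 200 ug/mL.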

Compound 4, half-maximal inhibitory concentration: > 100 ug/mL
Compound 4: no number, only a limit; the forecaster's own chance of this, stated with the estimate: 35%; middle value at least 1.1-fold (0.04 log units) from the limit.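

Compound 4 has only a limit in this assay, > 100 ug/mL, so a free hydroxyl on this ring does not by itself yield a readable number here. Among the compounds shown here, the one step that can be read is an at least 1.3-fold higher number from compound 2 to compound 4 (0.12 log units; that floor lies within the scatter); it is only a floor, so the true size of the change to 3-hydroxyphenyl in place of 4-hydroxy-3,5-dimethoxyphenyl remains unknown, and the steps to compound 4 from compound 3 and from compound 1 cannot be read. Of the hydrazones shown, compound 2 is now the only one with an actual number, while compound 3 and compound 4 both stop at the same edge of the read-out: the limit of > 100 ug/mL in this assay, at which 2 of the 4 values shown sit.

The compounds shown leave open how far beyond that edge compound 3 and compound 4 really lie, so the two cannot be placed in order. They also leave open what would happen on the carbon with a double bond to nitrogen if the phenyl group carried an amine or a carboxylic acid in place of the hydroxyl.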